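The source may report more compounds than this note shows. Statements on the series, on what has been measured and on what is new or still open speak of the compounds shown alone.

Working notes on the series. Compound 1 `O=C(NCc1ccccc1)c1cncc(Cl)n1` carries the shared core with a chlorine and the benzylamide; in an ADME assay on HEL cells (Homo sapiens) for cytotoxicity, read by microscopy, with a stated time of 6 days (on this read-out higher numbers stand for lower toxicity in this test and lower numbers for higher toxicity in this test), compound 1 shows "not determined" (no result reported). Compound 2 `CCCCCCCCNc1cncc(C(=O)NCc2ccccc2)n1` replaces that chlorine with an octylamino chain. In this assay compound 2 reaches only a limit of the assay, > 100000 nM. Compound 3 `CCCCNc1cncc(C(=O)NCc2ccccc2)n1` shortens the chain to butylamino. In this assay compound 3 likewise reaches only a limit, > 100000 nM. The step that the two limits leave unreadable from compound 2 to compound 3 cannot be read, since both ends sit at the limit; compound 3 therefore stands at the ceiling of what this test reports, with no number to rank it against compound 2.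

Compound 4 `CCCCCCNc1cncc(C(=O)NCc2ccccc2)n1` differs from compound 3 by ethyl in place of hydrogen on a saturated chain carbon, four bonds along the chain from a nitrogen on an aromatic ring. Among the measured compounds shown here, the only measured step, a step that the two limits leave unreadable from compound 2 to compound 3, spans hydrogen to butyl at this same place and gives no readable size, so no direction can be drawn from it; the limit of > 100000 nM in this assay, at which 2 of the 3 values shown sit, is the relevant observation, with both chain-bearing compounds unreadable there. Compound 4 is accordingly expected to show a number no higher from compound 3 to compound 4 (the limit leaves the size open), no movement beyond the scatter. The estimate for compound 4 in this assay is 100000 nM, within 50000 nM to 200000 nM, most probably again reported only as a limit.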

Compound 4, minimum cytotoxic concentration: > 100000 nM
Compound 4: a limit, no number; the forecaster's own chance of this, stated with the estimate: 85%; the middle value sits exactly at the limit.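

Compound 2, compound 3 and compound 4 all stand at a limit in this assay, so no step among them can be read: the limit of > 100000 nM in this assay, at which 3 of the 4 values shown sit.

The compounds shown leave open how these chains rank against one another in this assay, and whether any chain length gives a number there.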